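Bromophenyl Replaces Benzyloxy on the Shared Core

The source may hold more compounds than are shown below. What is called first, only, known or untested is meant among the compounds shown, and "the series" means these compounds.

Compound 1 `C=C[C@@](C)(/C=C/c1ccc(OCc2ccccc2)cc1)CCC=C(C)C` was tested in a functional assay on Raji cells (Homo sapiens) for cytotoxicity, with a stated time of 72 h; on this read-out lower numbers stand for an effect already at smaller amounts and higher numbers for an effect only at larger amounts of compound. In this assay compound 1 gives > 26000 nM, which is a limit of the assay rather than a number. Compound 2 `C=C[C@@](C)(/C=C/c1ccc(O)c(/C=C/c2ccc(Cl)c(Cl)c2)c1)CCC=C(C)C` was tested in the same way; in this assay compound 2 gives > 26000 nM, again a limit of the assay. For the measured compounds named here, compound 1 thus stands at the limit of > 26000 nM in this assay, at which 2 of the 2 values shown sit, and no compound measured so far has reached a numerical value. Compound 3 `C=C[C@@](C)(/C=C/c1ccc(-c2cccc(Br)c2)cc1)CCC=C(C)C` has not yet been measured in this assay. It differs from compound 1 in one place (3-bromophenyl in place of benzyloxy on an aromatic carbon). Going by the values given here, because both known values sit at the limit of > 26000 nM in this assay, at which 2 of the 2 values shown sit, no measured step shows what size of change such an exchange brings. The expected step is a step that the limit leaves unreadable from compound 1 to compound 3, that is, none beyond the usual scatter. Compound 3 is estimated at 30000 nM, within a range from 8000 nM to 100000 nM, and a limit may well be reported once more.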

Compound 3, half-maximal effective concentration: > 26000 nM
Compound 3 was reported as a limit (the forecaster's own chance of this, stated with the estimate: 75%); the middle value does not contradict the limit.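

No step can be read from compound 1 to compound 3, because both results are limits and not numbers: the limit of > 26000 nM in this assay, at which 3 of the 3 values shown sit. The compounds shown leave open whether 3-bromophenyl in place of benzyloxy changes the effect in this assay, and what numerical value any of them would give.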